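The source may hold more compounds than are shown below. What is called first, only, known or untested is meant among the compounds shown, and "the series" means these compounds.

Compound 2 `COc1cc(Cl)ccc1Oc1ccncc1CN(C)C` is a small molecule tested in an assay on HEK293 cells for inhibition of sodium-dependent dopamine transporter (Homo sapiens); on this read-out lower numbers stand for stronger inhibition and higher numbers for weaker inhibition. In this assay compound 2 gives 10200 nM, the highest of the two numbers available. Compound 3 `COc1cc(Cl)ccc1Oc1cc(C)ncc1CN(C)C`, which carries an extra methyl group on the core, gives 5040 nM; that single measured step is a 2.0-fold lower number from compound 2 to compound 3 (0.31 log units; beyond the scatter). Compound 1 `CNCc1cnccc1Oc1ccc(Cl)cc1OC`, a close relative without the methyl on the amine, has in this assay the entry "not determined" (no result reported).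

Compound 4 `Cc1cc(Cl)ccc1Oc1ccncc1CN(C)C` differs from compound 2 in one place: methyl in place of methoxy on an aromatic carbon. Among the measured compounds shown here, no measured step shows what swapping methoxy for methyl does here. For the measured compounds named here, the only step available, from compound 2 to compound 3, concerns a different position and was modest, so there is no firm basis for expecting a large shift in this assay in either direction. The most reasonable expectation is a change no larger than the scatter, with wide uncertainty. On that basis compound 4 is estimated at 8000 nM, with a range from 3000 nM to 25000 nM, which means an expected step of a 1.3-fold lower number from compound 2 to compound 4 (0.11 log units; within the scatter).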

Compound 4, half-maximal inhibitory concentration: 3230 nM
Beside the measured number, compound 4's estimate is 2.5-fold (0.39 log units) above it, within the range that was stated.
By their numbers in this assay, from the lowest: compounds 4 and 3 (each within the scatter of the next); then compound 2.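

In this assay the swap of methoxy for methyl on this aromatic carbon gives a 3.2-fold lower number from compound 2 to compound 4 (0.50 log units; beyond the scatter) and so shows that the ring carbon-only side of the molecule can also shift the number. Compound 4 lacks the oxygen of the methoxy group and still gives a lower number than compound 2, so that oxygen is not required for the inhibition seen here. Nothing measured here explains why this swap lowers the number.

As far as these compounds go, whether an ethyl group, a fluoro group or a plain hydrogen at this place would lower the number further, or raise it again, remains open. Also open, from the compounds shown here alone, is how this methyl would combine with the extra methyl on the core of compound 3.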